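The compounds below may be only part of what the source reports. "The series", "measured", "known", "first", "only" and "open" are said of these compounds alone.

Working notes on the series. In a functional assay on NCI-N87 cells (Homo sapiens) for antiproliferative activity, read by CCK-8 assay, with a stated time of 72 h (a higher number here means a weaker inhibitor, a lower number a stronger inhibitor), compound 1 `Cc1cc(Nc2cc(N3CCN(C)CC3)nc(Nc3ccc(Cl)cc3)n2)n[nH]1` gives 7470 nM. Compound 2 `COc1cccc(Nc2nc(Nc3cc(C)[nH]n3)cc(N3CCN(C)CC3)n2)c1` gives 7190 nM. Compound 3 `Cc1cc(Nc2cc(N3CCN(C)CC3)nc(Nc3cccc([N+](=O)[O-])c3)n2)n[nH]1` gives 4320 nM, which stands within the scatter of both other compounds, so the three cannot be ranked.

Compound 4 `Cc1cc(Nc2cc(N3CCN(C)CC3)nc(Nc3ccc(C#N)cc3)n2)n[nH]1` has not yet been measured. Its difference from compound 3 is 4-cyanophenyl in place of 3-nitrophenyl on a nitrogen on an aromatic ring. In short, this is 4-cyanophenyl in place of 3-nitrophenyl on a nitrogen on an aromatic ring.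

Three measured steps at this same place bear on the change: a 1.0-fold lower number from compound 1 to compound 2 (0.02 log units; within the scatter), a 1.7-fold lower number from compound 1 to compound 3 (0.24 log units; within the scatter) and a 1.7-fold lower number from compound 2 to compound 3 (0.22 log units; within the scatter). Among the measured compounds shown here, all three stay within the scatter, and no compound in this set goes against that. None of them tests a 4-cyanophenyl group, so the range is kept wide. No step beyond the scatter is expected in this assay. The estimated step is a 1.3-fold higher number from compound 3 to compound 4 (0.10 log units; within the scatter). For compound 4 the expected value is 5500 nM, with an estimated range from 2500 nM to 12000 nM.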

Compound 4, half-maximal inhibitory concentration: 5780 nM
Compound 4: middle estimate off by 1.1-fold (0.02 log units), on the low side; the range from low to high includes it.
By their numbers in this assay, from the lowest: compounds 3, 4, 2 and 1 (each within the scatter of the next).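

In this assay, the 4-cyanophenyl group adds a nitrile to the set on the same nitrogen, and its step from the 3-nitrophenyl compound stays within the scatter (a 1.3-fold higher number from compound 3 to compound 4 (0.13 log units; within the scatter)), as do its steps from the 3-methoxyphenyl compound (a 1.2-fold lower number from compound 2 to compound 4 (0.09 log units; within the scatter)) and the 4-chlorophenyl compound (a 1.3-fold lower number from compound 1 to compound 4 (0.11 log units; within the scatter)). Among the compounds shown here, the last of these is the first direct swap on the same aromatic carbon, cyano for chloro, and it separates the two groups no more than the earlier changes separated theirs. All four aryl groups therefore remain unranked at this place, and no measurement offered here accounts for the numbers.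

As far as these compounds go, it remains open whether any change at this nitrogen gives a step beyond the scatter. A carboxylic acid or an amine on the phenyl ring, or a longer chain in its place, would test this.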